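A few compounds are considered here, and "the series" means these few. Any claim that something is new, unique, unknown or untested is made for them only; others in the source may bear on it.

Working notes on the series. For the measured compounds named here, in a functional assay on MDA-MB-436 cells (Homo sapiens) for antiproliferative activity, read by MTT assay, with a stated time of 48 h (a higher number here means a weaker inhibitor, a lower number a stronger inhibitor), compound 1 (`CN1CCN(c2ccc(-c3cc4c(N5CCN(S(=O)(=O)N6CCCCC6)CC5)ncnc4s3)cc2)CC1`) gives 7570 nM and compound 2 (`CN1CCN(c2ccc(-c3cc4c(N5CCN(C(=O)Nc6ccc(OC(F)(F)F)cc6)CC5)ncnc4s3)cc2)CC1`) gives 6250 nM as the only numbers so far. These two values lie within the scatter of each other, so compound 2 cannot be ranked against compound 1. Compound 3 (`COc1ccccc1NC(=O)N1CCN(c2ncnc3sc(-c4ccc(N5CCN(C)CC5)cc4)cc23)CC1`) has no number yet. It differs from compound 2 by 2-methoxyphenyl in place of 4-(trifluoromethoxy)phenyl on an amide-type nitrogen with 2-methoxyphenyl in place of 4-(trifluoromethoxy)phenyl on an amide-type nitrogen. Going by the values given here, no measured step shows what a change at this place does. Compound 2 at 6250 nM is therefore the anchor for the expectation. The expected change is a 1.0-fold lower number from compound 2 to compound 3 (0.02 log units; within the scatter) and is estimated to stay within the scatter, with no direction favoured. For compound 3 the estimated value is 6000 nM with an expected range from 2500 nM to 14000 nM in this assay once measured.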

Compound 3, half-maximal inhibitory concentration: 26300 nM
The estimate for compound 3 lay 4.4-fold (0.64 log units) below the measured number; measured number outside the range, above it.
By their numbers in this assay, from the lowest: compounds 2 and 1 (each within the scatter of the next); then compound 3.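

For the compounds shown here, the aryl group on the amide-type nitrogen matters in this assay: 2-methoxyphenyl in place of 4-(trifluoromethoxy)phenyl gives a 4.2-fold higher number from compound 2 to compound 3 (0.62 log units; beyond the scatter), the first change at this place that lies beyond the scatter. The comparison with the sulfonyl side gives a 3.5-fold higher number from compound 1 to compound 3 (0.54 log units; beyond the scatter) on (2-methoxyphenyl)carbamoyl in place of (piperidin-1-yl)sulfonyl on an amine nitrogen in a ring, so compound 3 stands apart from both earlier compounds, which could not be ranked against each other. Nothing available bears on the reason for this shift.

The compounds shown do not separate the loss of the 4-(trifluoromethoxy) substituent from the arrival of the 2-methoxy substituent. On these data alone, a phenyl without any substituent on this nitrogen would help separate them, and an aryl group carrying an amine or a carboxylic acid remains open.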